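Trading a Pyrazole for a Methoxyethyl Chain on the Amide

The source may report more compounds than this note shows. Statements on the series, on what has been measured and on what is new or still open speak of the compounds shown alone.

Compound 1, with the structure `Cc1ccc(OCC(=O)N(Cc2cccs2)c2c[nH]nc2C)cc1`, is a phenoxyacetamide carrying a thiophene-methyl group and a small aromatic ring on its amide nitrogen. In an assay on HEK293 cells for agonist activity at transient receptor potential cation channel subfamily M member 8 (Homo sapiens), read by fluorescence and calcium flux, with a stated time of 15 min (on this read-out higher numbers stand for an effect only at larger amounts of compound and lower numbers for an effect already at smaller amounts), compound 1 gives 0.4 nM, the lowest of the two numbers recorded here. For the measured compounds named here, the nearest measured neighbour is compound 2, `CCN(Cc1cccs1)C(=O)c1cc2cc(C)ccc2[nH]1`, which is built on a different core and in this assay gives 2010 nM; the two compounds differ in several places at once, so the gap between them says only that the two values lie far apart. Compound 3, `CCN(Cc1cn[nH]c1)C(=O)COc1ccc(C)cc1`, is reported in this assay as "active" (no number reported) without a number.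

Compound 4, `COCCN(Cc1cccs1)C(=O)COc1ccc(C)cc1`, is the compound not yet measured. It differs from compound 1 in a single place: 2-methoxyethyl in place of 3-methyl-1H-pyrazol-4-yl on an amide-type nitrogen. A flat ring that carries both a donor and an acceptor is swapped for a short chain with an acceptor only.

Going by the values given here, no measured pair shows this exact change, so the expectation rests on the potency of compound 1 at 0.4 nM and on the weak number of compound 2. Compound 4 is expected to need clearly more substance than compound 1, with the step of a 500-fold higher number from compound 1 to compound 4 (2.70 log units; beyond the scatter) expected to lie well beyond the scatter. The estimate for compound 4 is 200 nM, within a range from 20 nM to 3000 nM.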

Compound 4, half-maximal effective concentration: 400 nM
For compound 4 the middle estimate is 2.0-fold (0.30 log units) below the measured one, and the stated range covers the measured number.
By their numbers in this assay, from the lowest: compound 1; then compound 4; then compound 2.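

For the compounds shown here, this is the first pair here that differs in one place only, so the group on the amide-type nitrogen can now be judged on its own: in this assay, 2-methoxyethyl in place of 3-methyl-1H-pyrazol-4-yl gives a 1000-fold higher number from compound 1 to compound 4 (3.00 log units; beyond the scatter). The identity of this group therefore has a very large effect on the read-out, though compound 4 keeps a measurable effect at 400 nM in the same test. The swap removes the ring and the hydrogen-bond donor together while the count of hydrogen-bond acceptors stays the same, and no measurement here bears on what lies behind the step.

On these data alone, a single pair cannot separate the loss of the ring from the loss of the donor, so it stays open whether a plain phenyl ring, or a chain ending in a hydroxyl group or an amine, would bring the number back towards that of compound 1. Going by these compounds alone, compound 3 is reported only as active, without a number, so it offers no second step to set beside this one.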